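A few compounds are considered here, and "the series" means these few. Any claim that something is new, unique, unknown or untested is made for them only; others in the source may bear on it.

Working notes on the series. Three compounds have numbers in a functional assay on MCF7 cells (Homo sapiens) for cytotoxicity, read by MTT assay, with a stated time of 72 h; a lower number here means a stronger inhibitor of growth, a higher number a weaker inhibitor of growth. Compound 1 `COc1ccc(CNc2nc([Se]C)nc3ccccc23)cc1` gives 42200 nM and compound 2 `CCCCC[Se]c1nc([Se]CCCCC)c2cccnc2n1` gives 40800 nM. Compound 3 `CSc1ccc(CNc2nc(SC)nc3ncccc23)cc1` gives 50 nM, the lowest of the three, and its gap to both compound 2 and compound 1 lies well beyond the scatter, so compound 3 stands alone as the most potent of the measured set.

Compound 4 `COc1ccc(CNc2nc(SC)nc3ncccc23)cc1` is not yet measured. Against compound 3 the change is methoxy in place of methylsulfanyl on an aromatic carbon. Within the data shown here, no measured pair isolates this swap; compound 1 carries a methoxy on its benzyl ring but differs elsewhere as well, so it cannot set the step. A modest loss is expected, with the step from compound 3 to compound 4 estimated at a 4.0-fold higher number from compound 3 to compound 4 (0.60 log units; beyond the scatter) in this assay. Compound 4 is expected at 200 nM, within 40 nM to 2000 nM.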

Compound 4, concentration for 50% growth inhibition: 48100 nM
The estimate for compound 4 lay 240-fold (2.38 log units) below the measured number; measured number above the stated range.
By their numbers in this assay, from the lowest: compound 3; then compounds 2, 1 and 4 (each within the scatter of the next).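

In this assay, among these compounds, methoxy in place of methylsulfanyl on an aromatic carbon, para to a large group, gives a 960-fold higher number from compound 3 to compound 4 (2.98 log units; beyond the scatter) and shows that this one position is highly sensitive to the swap, which the earlier compounds could not isolate. The two groups match in heavy-atom, donor and acceptor counts, so those counts do not separate them. No measurement at hand accounts for the step.

Whether the low number of compound 3 depends on sulfur stays open, since ethylsulfanyl, a chlorine atom or a plain hydrogen at this position is not among the compounds shown. Going by these compounds, whether the same swap costs as much on another core also remains unknown.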